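The compounds below may be only part of what the source reports. "The series", "measured", "known", "first", "only" and "open" are said of these compounds alone.

Two ureas carrying the same difluorinated aromatic ring have been measured in an assay on microsomes from intestinal mucosa for inhibition of acyl-CoA:cholesterol acyltransferase (Oryctolagus cuniculus); on this read-out higher numbers stand for weaker inhibition and lower numbers for stronger inhibition. Compound 1, `CCCCCCCC/C=C\CCCCCCCCNC(=O)Nc1ccc(F)cc1F`, gives 4700 nM in this assay. Compound 2, `CCCCCCCCCCCCCCNC(=O)Nc1ccc(F)cc1F`, gives 340 nM in this assay. Among the compounds with values here, the one change between them lies in the chain: a 14-fold lower number from compound 1 to compound 2 (1.14 log units; beyond the scatter). On these two numbers compound 2 stands lowest, and its nearest neighbour is compound 1, which sits well above it.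

Compound 3, `CCCCCCCCCCCCCCNC(=O)Nc1c(F)cc(F)cc1F`, has not yet been measured. It differs from compound 2 only on the ring: fluoro in place of hydrogen on an aromatic carbon, placed on an aromatic carbon of a six-membered aromatic ring of carbon only, ortho to a large group and meta to two fluoro groups; read one bond further out, 2,4-difluorophenyl becomes 2,4,6-trifluorophenyl. Within the data shown here, the single measured step concerns the chain, not the ring, so no measured step bears on this change. The expected step from compound 2 is therefore no change at the digits printed from compound 2 to compound 3 (within the scatter), a change not expected to exceed the scatter in this assay. For compound 3 the estimated value in this assay is 340 nM, with a range from 110 nM to 1100 nM.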

Compound 3, half-maximal inhibitory concentration: 250 nM
The estimate for compound 3 lay 1.4-fold (0.13 log units) above the measured number; low and high end bracket the measured number.
By their numbers in this assay, from the lowest: compounds 3 and 2 (each within the scatter of the next); then compound 1.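

The ring now has a measured step of its own. In this assay, within the data shown here, fluoro in place of hydrogen on this aromatic carbon, ortho to a large group and meta to two fluoro groups, gives a 1.4-fold lower number from compound 2 to compound 3 (0.13 log units; within the scatter), so the two ureas cannot be told apart on this read-out, and this position takes a fluoro without a measurable loss, whereas the only large step so far, a 14-fold lower number from compound 1 to compound 2 (1.14 log units; beyond the scatter), lies in the chain. Nothing at hand explains why the added fluoro leaves the number within the scatter.

As far as these compounds go, a fluoro is a small group, so it remains open whether the same aromatic carbon would also tolerate a larger substituent such as chloro, methyl or methoxy, or a charged one such as an amine or a carboxylic acid. From the compounds shown here alone, it is equally open whether the 2,4,6-trifluorophenyl ring would behave the same way on a longer chain or on the unsaturated chain of compound 1, since this single step was read on one chain only.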